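Cyano for trifluoromethyl on the core of compound 1

The source may hold more compounds than are shown below. What is called first, only, known or untested is meant among the compounds shown, and "the series" means these compounds.

Compound 1 `O=[N+]([O-])c1ccccc1CNc1cc(C(F)(F)F)cc2[nH]ncc12` is the reference point of this set. Among the compounds with values here, in an assay for inhibition of Indoleamine 2,3-dioxygenase 1 (Homo sapiens), with stated times of 10 min and 60 min (on this read-out lower numbers stand for stronger inhibition and higher numbers for weaker inhibition), compound 1 gives 14000 nM, one of only two numbers recorded, alongside compound 3 `O=[N+]([O-])c1cc(Cl)ccc1CNc1cc(C(F)(F)F)cc2[nH]ncc12` at 18000 nM; the step of a 1.3-fold higher number from compound 1 to compound 3 (0.11 log units; within the scatter) sits within the scatter. Compound 2 `CC(C)n1ncc2c(NCc3ccccc3[N+](=O)[O-])cc(C(F)(F)F)cc21` reaches only a limit of the assay, > 100000 nM in this assay, so the step of an at least 7.1-fold higher number from compound 1 to compound 2 (0.85 log units; beyond the scatter) is read against (the limit of > 100000 nM in this assay, at which 1 of the 3 values shown sits).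

Compound 4 `N#Cc1cc(NCc2ccccc2[N+](=O)[O-])c2cn[nH]c2c1` is not yet measured. It differs from compound 1 by cyano in place of trifluoromethyl on an aromatic carbon. Within the data shown here, neither measured step touches that position: the step to compound 2 alters an aromatic nitrogen and the step to compound 3 another aromatic carbon, so no measured step bears directly on the exchange of trifluoromethyl for cyano. With nothing to push the number either way, the expected step of a 1.1-fold higher number from compound 1 to compound 4 (0.03 log units; within the scatter) is none beyond the scatter, though the range is kept wide. Compound 4 is therefore estimated at 15000 nM in this assay, between 4000 nM and 60000 nM.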

Compound 4, half-maximal inhibitory concentration: > 100000 nM
Compound 4 ended at the assay's limit; the forecaster's own chance of this, stated with the estimate: 10%; at least 6.6-fold (0.82 log units) between middle value and limit.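

Within the data shown here, the aromatic carbon carrying trifluoromethyl on the core of compound 1 is the first position where a change on an aromatic carbon moves the number beyond the scatter: this assay shows an at least 7.1-fold higher number from compound 1 to compound 4 (0.85 log units; beyond the scatter). Among these compounds, the only earlier change on an aromatic carbon, at another position, gave a 1.3-fold higher number from compound 1 to compound 3 (0.11 log units; within the scatter), so the series is not equally tolerant at every aromatic carbon. Compound 4 stands at a limit, not at a number, so the step fixes a direction and no exact size: the limit of > 100000 nM in this assay, at which 2 of the 4 values shown sit.

With only trifluoromethyl and cyano shown at this position, it stays open whether the difference follows from losing trifluoromethyl or from introducing cyano. A methyl group, an amine or a carboxylic acid in the same place would help separate these two readings.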